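Working notes: from compound 2 to compound 4

A few compounds are considered here, and "the series" means these few. Any claim that something is new, unique, unknown or untested is made for them only; others in the source may bear on it.

Measured in a functional assay on HT-29 cells (Homo sapiens) for cytotoxicity, read by MTT assay, with a stated time of 24 h; a lower number here means a stronger inhibitor, a higher number a weaker inhibitor:
- compound 1 `C[C@H]1O[C@]1(C)C(=O)C[C@@H]1[C@@]2(C)[C@@H](O)CCC(C)(C)[C@]2(O)CC[C@@]1(C)O`: > 10000 nM, a limit
- compound 2 `C[C@@H]1O[C@@]1(C)C(=O)C[C@@H]1[C@@]2(C)[C@@H](O)CCC(C)(C)[C@]2(O)CC[C@@]1(C)O`: > 10000 nM, a limit
- compound 3 `C[C@@H]1O[C@@]1(C)C(=O)C[C@H]1[C@](C)(O)CC[C@@]2(O)C(C)(C)CCC[C@]12C`: > 10000 nM, a limit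

Compound 2 gives > 10000 nM, which is a limit and not a number. It therefore has no readable position within the series, and the same applies to compound 1 and compound 3, as the limit of > 10000 nM in this assay, at which 3 of the 3 values shown sit, shows.

Compound 4 `C/C=C(\C)C(=O)C[C@@H]1[C@@]2(C)[C@@H](O)CCC(C)(C)[C@]2(O)CC[C@@]1(C)O` is related to compound 2 by this change: 1-methylprop-1-en-1-yl in place of 2,3-dimethyloxiran-2-yl on a carbonyl carbon. In words, the 2,3-dimethyloxiran-2-yl group on the carbonyl carbon gives way to 1-methylprop-1-en-1-yl.

For the measured compounds named here, two measured steps bear on this change, and only loosely. Going by the values given here, the first is a step that the two limits leave unreadable from compound 1 to compound 2, and it comes with the fact that compounds 1 and 2 differ only in the configuration as drawn. The second is a step that the two limits leave unreadable from compound 2 to compound 3. Among the compounds with values here, neither has a size that can be used, and no measured compound carries the 1-methylprop-1-en-1-yl group.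

Within the data shown here, no step of known size therefore supports a shift in either direction in this assay, and none beyond the scatter is expected. The expected step is a step that the limit leaves unreadable from compound 2 to compound 4. Compound 4 may well be reported only as a limit again. For compound 4 the estimate is 20000 nM, with an expected range from 8000 nM to 60000 nM.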

Compound 4, half-maximal inhibitory concentration: > 10000 nM
Compound 4 gave a limit, no number; the forecaster's own chance of this, stated with the estimate: 80%; the middle value is on the limit's open side.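

In this assay compound 4 gives > 10000 nM, which is a limit and not a number. No new step can be read between compound 4 and compound 1 or compound 2, because all of them sit at one limit: the limit of > 10000 nM in this assay, at which 4 of the 4 values shown sit.

The compounds shown leave open whether replacing 2,3-dimethyloxiran-2-yl with 1-methylprop-1-en-1-yl changes activity in this assay at all.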